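A hydroxyethoxy end in place of pyridinylamino

The compounds below may be only part of what the source reports. "The series", "measured", "known", "first", "only" and "open" are said of these compounds alone.

Three measured compounds share one core and differ at the end of the chain: compound 1 (`c1ccc(COc2ccc(OCCOCCNC3CCCC3)cc2)cc1`), compound 2 (`c1ccc(COc2ccc(OCCOCCOC3CCCC3)cc2)cc1`) and compound 3 (`c1ccc(COc2ccc(OCCOCCNc3ccncc3)cc2)cc1`). In a functional assay on SK-OV-3 cells (Homo sapiens) for inhibition, read by CCK-8 assay, with a stated time of 70 h (a higher number here means a weaker inhibitor, a lower number a stronger inhibitor), compound 3 gives 20600 nM and compound 1 gives 24800 nM, so the two stand level, a 1.2-fold lower number from compound 1 to compound 3 (0.08 log units; within the scatter). Compound 2 reads > 100000 nM, which is a limit of the assay and not a number.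

Compound 4 (`OCCOCCOCCOc1ccc(OCc2ccccc2)cc1`) has 2-hydroxyethoxy in place of (pyridin-4-yl)amino on a saturated chain carbon, two bonds along the chain from an oxygen on a saturated carbon. Among the measured compounds shown here, compound 2 is the only measured compound that, like compound 4, has no amino group on that carbon, so two steps bear most directly: an at least 4.0-fold higher number from compound 1 to compound 2 (0.60 log units; beyond the scatter) and an at least 4.8-fold lower number from compound 2 to compound 3 (0.68 log units; beyond the scatter). For the measured compounds named here, both are bounded by a limit, and no measured compound carries 2-hydroxyethoxy itself, so the transfer is uncertain. A move of modest size towards weaker inhibition is therefore expected in this assay, and the estimated change is a 3.4-fold higher number from compound 3 to compound 4 (0.53 log units; beyond the scatter). For compound 4 the estimate is 70000 nM, with an expected range from 25000 nM to 150000 nM.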

Compound 4, half-maximal inhibitory concentration: 59400 nM
Compound 4: the middle estimate sits 1.2-fold (0.07 log units) above what was measured, and the stated range covers the measured number.
By their numbers in this assay, from the lowest: compounds 3 and 1 (each within the scatter of the next); then compound 4. At a limit, above all of these: compound 2.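

In this assay, compound 4 shows that a chain end with no amino group can still give a readable number, though a weaker one than either amino end: a 2.9-fold higher number from compound 3 to compound 4 (0.46 log units; beyond the scatter), and a 2.4-fold higher number from compound 1 to compound 4 (0.38 log units; beyond the scatter). Compound 2 stands at a limit and not a number, so the change from cyclopentyl to 2-hydroxyethyl on the oxygen gives only a bound, an at least 1.6-fold lower number from compound 2 to compound 4 (0.22 log units; that floor lies within the scatter). Across these four compounds the two amino ends have the lowest numbers and the two ether ends the highest, yet compound 4 shows that losing the amino group does not by itself carry the number to the limit: the limit of > 100000 nM in this assay, at which 1 of the 4 values shown sits.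

The step from compound 3 to compound 4 removes the amino nitrogen and the pyridin-4-yl ring together, so the compounds shown cannot tell which of the two changes accounts for the shift. A simple 2-aminoethoxy end, a carboxylic acid or a longer chain ending in a hydroxyl group would be needed to show how far the weaker reading of compound 4 depends on the terminal hydroxyl group, the ether oxygen or the length of the chain.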